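Replacing a hydroxyl arm with a carbamoyl-bearing chain

The source may report more compounds than this note shows. Statements on the series, on what has been measured and on what is new or still open speak of the compounds shown alone.

Of the compounds shown here, three sharing one core have been tested in a functional assay on KG-1 cells (Homo sapiens) for antiproliferative activity; on this read-out lower numbers stand for an effect already at smaller amounts and higher numbers for an effect only at larger amounts of compound. Compound 1 `COCC(C)(C)C#Cc1c(Cl)c2c(Cl)cc(C(N)=O)nc2n1[C@H]1CCCNC1` gives 219 nM; compound 2 `CN1CC(C#Cc2c(Cl)c3c(Cl)cc(C(N)=O)nc3n2[C@H]2CCCNC2)CC1=O` gives 155 nM; compound 3 `CC(O)CC#Cc1c(Cl)c2c(Cl)cc(C(N)=O)nc2n1[C@H]1CCCNC1` gives 48 nM, the lowest of the three, with steps beyond the scatter to both others: a 4.6-fold lower number from compound 1 to compound 3 (0.66 log units; beyond the scatter) and a 3.2-fold lower number from compound 2 to compound 3 (0.51 log units; beyond the scatter), while a 1.4-fold lower number from compound 1 to compound 2 (0.15 log units; within the scatter). Compound 4 `CC(C)(CC#Cc1c(Cl)c2c(Cl)cc(C(N)=O)nc2n1[C@H]1CCCNC1)C(N)=O` carries 1-carbamoyl-1-methylethyl in place of 1-hydroxyethyl on a saturated chain carbon bound to a triple-bonded carbon. Its branched, doubly methylated chain recalls compound 1, and its amide recalls compound 2, both of which gave higher numbers than compound 3. The step of a 2.5-fold higher number from compound 3 to compound 4 (0.40 log units; beyond the scatter) is therefore expected to run upward, modestly. In this assay compound 4 is estimated at 120 nM, within a range of 45 nM to 320 nM.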

Compound 4, half-maximal effective concentration: 269 nM
Estimate against measurement, compound 4: 2.2-fold (0.35 log units) below; measured number inside the range.
By their numbers in this assay, from the lowest: compound 3; then compounds 2, 1 and 4 (each within the scatter of the next).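

Swapping 1-hydroxyethyl for 1-carbamoyl-1-methylethyl on a saturated chain carbon bound to a triple-bonded carbon is not tolerated as well in this assay, with a 5.6-fold higher number from compound 3 to compound 4 (0.75 log units; beyond the scatter) as the step beyond the scatter. The new arm instead sits with the other two, showing a 1.7-fold higher number from compound 2 to compound 4 (0.24 log units; within the scatter) and a 1.2-fold higher number from compound 1 to compound 4 (0.09 log units; within the scatter), so only the 2-hydroxypropyl arm of compound 3 stands apart among these four. Nothing measured here explains this difference.

From the compounds shown here alone, it remains open whether the added methyl groups or the amide drives the rise, and how a carboxylic acid or an amine at the end of this chain would read.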